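Swapping the anilino group of a weakly cytotoxic analogue

The compounds below may be only part of what the source reports. "The series", "measured", "known", "first", "only" and "open" are said of these compounds alone.

Compound 2 `CCOc1ccccc1Nc1nc(SCc2ccc(C(F)(F)F)cc2)nc2ccccc12` carries a 2-ethoxyphenyl group on a nitrogen on an aromatic ring. In a functional assay on MGC-803 cells (Homo sapiens) for cytotoxicity, read by MTT assay, with a stated time of 72 h (on this read-out higher numbers stand for weaker inhibition and lower numbers for stronger inhibition), compound 2 reaches only the assay limit, reported as > 50000 nM rather than a number. Compound 1 `CCCCCCCCCCCCCCNc1nc(SCc2ccc(C(F)(F)F)cc2)nc2ccccc12` likewise stops at the limit, giving > 50000 nM in this assay. For the measured compounds named here, compound 3 `FC(F)(F)c1ccc(CSc2nc(Nc3ccc(Cl)cc3)c3ccccc3n2)cc1`, bearing 4-chlorophenyl, gives 16800 nM in this assay; the step of an at least 2.9-fold lower number from compound 2 to compound 3 (0.47 log units; beyond the scatter) is the only measured step that bears on the change considered here, and its size rests on (the limit of > 50000 nM in this assay, at which 2 of the 3 values shown sit). Compound 4 `FC(F)(F)c1ccc(CSc2nc(Nc3ccc(C(F)(F)F)cc3)c3ccccc3n2)cc1` differs from compound 2 by 4-(trifluoromethyl)phenyl in place of 2-ethoxyphenyl on a nitrogen on an aromatic ring. Given the step of an at least 2.9-fold lower number from compound 2 to compound 3 (0.47 log units; beyond the scatter) seen with compound 3, a comparable lowering is expected for compound 4, about an at least 2.5-fold lower number from compound 2 to compound 4 (0.39 log units; beyond the scatter). Compound 4 is therefore estimated at 20000 nM, within 7000 nM to 60000 nM.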

Compound 4, half-maximal inhibitory concentration: 6170 nM
The estimate for compound 4 lay 3.2-fold (0.51 log units) above the measured number; measured number below the stated range.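

In this assay, the group on the nitrogen still moves the read-out once an aryl group that gives a measurable value is in place: trifluoromethyl in place of chloro gives a 2.7-fold lower number from compound 3 to compound 4 (0.44 log units; beyond the scatter). This shows that the outcome depends on the particular group on the aromatic ring, not only on leaving 2-ethoxyphenyl behind. The change from 2-ethoxyphenyl to 4-(trifluoromethyl)phenyl gives an at least 8.1-fold lower number from compound 2 to compound 4 (0.90 log units; beyond the scatter), a size known only as a bound: the limit of > 50000 nM in this assay, at which 2 of the 4 values shown sit.

As far as these compounds go, whether an amine or a carboxylic acid in place of trifluoromethyl would continue this trend remains open. The values of compound 3 and compound 4 show a difference. They do not explain it.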